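The compounds below may be only part of what the source reports. "The series", "measured", "known", "first", "only" and "open" are said of these compounds alone.

Compound 1, `N=C(NCCCc1c[nH]cn1)NCCC(c1ccccc1)c1ccccn1`, is the point of departure. In a functional assay on muscle tissue for agonist activity at histamine H2 receptor (Cavia porcellus) (a higher number here means a larger maximal response, a lower number a smaller maximal response), compound 1 gives 0.7. Two close relatives have been measured alongside it. Compound 2, `N=C(NCCCc1c[nH]cn1)NCCC(c1ccc(F)cc1)c1ccccn1`, gives 0.8 in this assay, and compound 3, `N=C(NCCCc1c[nH]cn1)NCCC(c1cccc(C(F)(F)F)c1)c1ccccn1`, gives 0.7. The step a number 0.10 higher from compound 1 to compound 2 (within the scatter) and the step of no change at the digits printed from compound 1 to compound 3 (within the scatter) both stay within the scatter, as does the step a number 0.10 lower from compound 2 to compound 3 (within the scatter). On these numbers compound 1 stands level with compound 3 at the digits shown, and compound 2 lies within the scatter of both, so no ordering of the three can be read from the data.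

The next compound, compound 4, is `N=C(NCCCc1c[nH]cn1)NCCC(c1ccc(Cl)c(Cl)c1)c1ccccn1`. The change from compound 1 is 3,4-dichlorophenyl in place of phenyl on a saturated chain carbon bound to an aromatic carbon and a saturated chain carbon. Among the measured compounds shown here, the steps that bear on it are those from compound 1 to compound 2 and from compound 1 to compound 3, since each of them also alters the same phenyl group of compound 1; neither moved the intrinsic activity beyond the scatter. By that reasoning the step of no change at the digits printed from compound 1 to compound 4 (within the scatter) is expected to be small, with no direction that can be defended beyond the scatter. Compound 4 is therefore estimated to give 0.7 in this assay, with a range from 0.55 to 0.9.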

Compound 4, intrinsic activity: the largest response reached, as a fraction of the reference agonist's: 0.8
Beside the measured number, compound 4's estimate is 0.10 below it; the measured number falls inside the stated range.
By their numbers in this assay, from the lowest: compounds 1, 3, 2 and 4 (each within the scatter of the next).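

The phenyl group of compound 1, on a saturated chain carbon bound to an aromatic carbon and a saturated chain carbon, can carry two chlorine atoms, going from 6 to 8 heavy atoms, and the step in this assay is a number 0.10 higher from compound 1 to compound 4 (within the scatter). Compound 4 is the first compound shown with two substituents on this aromatic ring, yet the read-out does not separate it from the compounds with one: the steps are no change at the digits printed from compound 2 to compound 4 (within the scatter) and a number 0.10 higher from compound 3 to compound 4 (within the scatter). Nothing available accounts for these numbers or links them to any property of the groups.

The compounds shown leave open whether any change at this position gives a step beyond the scatter, since all those shown are halogen or trifluoromethyl substitutions of the same phenyl group. An amine or a carboxylic acid on that aromatic ring, or a longer chain in place of the propyl chain to the shared core, might behave differently in this assay, and these compounds cannot say whether it would.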